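A few compounds are considered here, and "the series" means these few. Any claim that something is new, unique, unknown or untested is made for them only; others in the source may bear on it.

Of the compounds shown here, three have so far been measured in a physicochemical assay for lipophilicity, read by HPLC, measured as chromatographic lipophilicity, at pH 7.4; a higher number here means a more lipophilic compound, a lower number a more polar compound. Compound 1 `O=C(c1ccccc1)N1CCC(C(=O)N2N=CCC2c2ccccc2)CC1` gives 4.4 in this assay. Compound 3 `O=C(C1CCC1)N1N=CCC1c1ccccc1` gives 4.7, and compound 2 `CC(C)(C)C(=O)N1N=CCC1c1ccc(S(C)(=O)=O)cc1` gives 4.1. The number for compound 1 sits in the middle of the three, but both other numbers fall within the usual scatter of it, so on this measure the three compounds cannot be told apart, and none of them can be called the most or least lipophilic.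

Compound 4 `O=C(c1cocn1)N1CCC(C(=O)N2N=CCC2c2ccccc2)CC1` shares the core of compound 1 and differs from it in one place: 1,3-oxazol-4-yl in place of phenyl on a carbonyl carbon. Going by the values given here, no pair of measured compounds shows a change of this kind, so there is no measured step to read its effect from. The expectation must therefore rest on the number for compound 1, 4.4, and on the nature of the change, a phenyl leaving and a 1,3-oxazol-4-yl entering on the carbonyl carbon. The step from compound 1 to compound 4 in this assay is expected to be a number 1.10 log units lower from compound 1 to compound 4 (beyond the scatter), a fall beyond the scatter rather than no change. Compound 4 is accordingly estimated to give 3.3, with a likely range from 2.8 to 3.8. What the measurement actually shows remains to be seen.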

Compound 4, distribution coefficient: 2.9
Compound 4: middle estimate off by 0.40 log units, on the high side; low and high end bracket the measured number.
By their numbers in this assay, from the lowest: compound 4; then compounds 2, 1 and 3 (each within the scatter of the next, the first and the last beyond it).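

In this assay, 1,3-oxazol-4-yl in place of phenyl on a carbonyl carbon gives a number 1.50 log units lower from compound 1 to compound 4 (beyond the scatter), a large step and the first in this set that comes from a change in one place only. The earlier compounds shown here differed from one another in more than one place, so they could not show that the number responds to the group on this carbonyl carbon; this pair shows that it does, at least for this one replacement on the core of compound 1. The change alters several things at once, with a five-membered aromatic ring with 2 hetero atoms and 2 hydrogen-bond acceptors entering where a six-membered ring of carbon only and no acceptors leaves, and nothing measured here links the size of the step to any one of these differences.

With a single replacement shown, it remains open whether a pyridin-3-yl ring, which would keep the six-membered ring and add one ring nitrogen, would give a step nearer to this one or to no change. Going by these compounds, it is also open whether a non-aromatic group on the same carbonyl carbon, such as a morpholine or a short alkyl chain, would follow the phenyl or the 1,3-oxazol-4-yl.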